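Removing One Fluorine From a Sulfonamide Aryl Ring

The source may hold more compounds than are shown below. What is called first, only, known or untested is meant among the compounds shown, and "the series" means these compounds.

Compound 1 `O=C(NCc1ccc(CNS(=O)(=O)c2ccc3c(c2)CCO3)cc1)c1ccc(F)cc1`: in an assay on MDA-MB-231 cells for binding affinity to C-X-C chemokine receptor type 4 (Homo sapiens), read by fluorescence and microscopy, with stated times of 10 min and 30 min (on this read-out higher numbers stand for an effect only at larger amounts of compound and lower numbers for an effect already at smaller amounts), compound 1 gives 10 nM.
Compound 2 `O=C(NCc1ccc(CNS(=O)(=O)c2ccccc2Cl)cc1)c1ccc(F)cc1`: in this assay compound 2 gives 1000 nM.
Compound 3 `O=C(NCc1ccc(CNS(=O)(=O)c2ccc(F)c(F)c2)cc1)c1ccc(F)cc1`: in this assay compound 3 gives 10 nM.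

All three share the same core, and they differ only in the aromatic group attached to the sulfonyl sulfur. Compound 3 sits level with compound 1 at the digits shown, and together they give the lowest numbers of the three; the only large movement in the set is a 100-fold lower number from compound 2 to compound 3 (2.00 log units; beyond the scatter), with a 100-fold higher number from compound 1 to compound 2 (2.00 log units; beyond the scatter) telling the same story from the other side, while no change at the digits printed from compound 1 to compound 3 (within the scatter).

Compound 4 `O=C(NCc1ccc(CNS(=O)(=O)c2cccc(F)c2)cc1)c1ccc(F)cc1` has not yet been measured. The change that leads to it is hydrogen in place of fluoro on an aromatic carbon, leaving a single fluoro on the ring.

Going by the values given here, no measured step removes a fluoro from this ring on its own, so none bears on it directly. What the set does show is that two rather different groups, in compound 1 and compound 3, land at the same number, whereas compound 2 stands far apart. A small loss of one fluorine looks closer to the first kind of change than to the second, so in this assay compound 4 is expected to stay within the scatter, as a 1.5-fold higher number from compound 3 to compound 4 (0.18 log units; within the scatter). The estimate for compound 4 is 15 nM, with a range from 5 nM to 60 nM.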

Compound 4, effective concentration (reported as EC, without a stated level of effect): 1000 nM
Estimate against measurement, compound 4: 67-fold (1.82 log units) below; measured number outside the range, above it.
By their numbers in this assay, from the lowest: compounds 1 and 3 (each within the scatter of the next); then compounds 2 and 4 (each within the scatter of the next).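

In this assay, going by these compounds alone, the earlier compounds differed by whole groups on the sulfonyl sulfur, so none of them showed what a single atom on the ring can do. Here one atom changes, with hydrogen entering on an aromatic carbon ortho to a fluoro group and para to a large group, and that alone gives a 100-fold higher number from compound 3 to compound 4 (2.00 log units; beyond the scatter) in this set. The 3-fluorophenyl ring also falls in with the 2-chlorophenyl ring, as no change at the digits printed from compound 2 to compound 4 (within the scatter) shows, and the gap to the ring of compound 1 reads a 100-fold higher number from compound 1 to compound 4 (2.00 log units; beyond the scatter) so that one fluoro on the ring does not by itself hold the low number, and the fluoro that leaves compound 3 counts for a great deal. No measurement available here explains why one atom moves the number this far.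

As far as these compounds go, it remains open whether the low number needs fluoro in that place or whether a chloro, a methyl or a methoxy group there would hold it as well. Also open, from the compounds shown here alone, is whether the fluoro that stays on the ring of compound 3 is needed at all, which a ring with hydrogen in its place would show.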